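Swapping methyl for chloro on an aromatic carbon

The compounds below may be only part of what the source reports. "The series", "measured", "known", "first", "only" and "open" are said of these compounds alone.

Measured in a functional assay on J774 cells (Mus musculus) for cytotoxicity, read by resazurin assay; a higher number here means a weaker inhibitor, a lower number a stronger inhibitor:
Compound 1 `OCCCCCC(O)c1ccc(-c2ccccc2)cc1` gives 22000 nM
Compound 2 `Cc1cccc(-c2ccc(C(O)CCCCCO)cc2)c1` gives > 100000 nM (a limit, not a number)
Compound 3 `CSc1ccc(-c2ccc(C(O)CCCCCO)cc2)cc1` gives 24000 nM

Compound 2 has only a limit of the assay, > 100000 nM (no exact number).

Compound 4 `OCCCCCC(O)c1ccc(-c2cccc(Cl)c2)cc1` carries chloro in place of methyl on an aromatic carbon (3-methylphenyl to 3-chlorophenyl). Within the data shown here, no measured step makes this exchange directly, so two related steps have to serve. Methyl in place of hydrogen moved the number beyond the scatter (an at least 4.5-fold higher number from compound 1 to compound 2 (0.65 log units; beyond the scatter)), while methylsulfanyl in place of hydrogen did not (a 1.1-fold higher number from compound 1 to compound 3 (0.04 log units; within the scatter)). With that methyl gone and chloro untested so far, compound 4 is expected to fall back towards compound 1 (22000 nM) and compound 3 (24000 nM).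

The expected step in this assay is an at least 2.2-fold lower number from compound 2 to compound 4 (0.34 log units; beyond the scatter) (a lower number, though only loosely known). For compound 4 the estimate is 45000 nM (expected range 15000 nM to 100000 nM).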

Compound 4, half-maximal inhibitory concentration: > 100000 nM
Compound 4: only a limit was reported (the forecaster's own chance of this, stated with the estimate: 30%); middle value at least 2.2-fold (0.34 log units) away from the limit.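

In this assay compound 4 gives > 100000 nM, which is a limit and not a number. Chloro in place of hydrogen gives an at least 4.5-fold higher number from compound 1 to compound 4 (0.65 log units; beyond the scatter), so the 3-chlorophenyl group of compound 4 joins the 3-methylphenyl group of compound 2 in moving the number beyond the scatter, a shift that until now rested on methyl alone, while compound 3, with methylsulfanyl, goes against this pattern by staying within the scatter of compound 1. The step from methyl to chloro cannot be read, because compound 2 and compound 4 both stop at the same limit: the limit of > 100000 nM in this assay, at which 2 of the 4 values shown sit.

From the compounds shown here alone, how far apart compound 2 and compound 4 truly lie remains open. Also open, going by these compounds, is whether an amine or a carboxylic acid at this place would move the number as methyl and chloro do, or leave it near the value of compound 1, 22000 nM.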